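A single number and one group swapped

A few compounds are considered here, and "the series" means these few. Any claim that something is new, unique, unknown or untested is made for them only; others in the source may bear on it.

compound 1 `CCNC(=O)Nc1sc2ccccc2c1C(=O)N1CCN(C2CCN(C(=O)CC)CC2)CC1` gives "not determined" (no result reported)
compound 2 `CCNC(=O)Nc1sc2ccccc2c1C(=O)N1CCN(C2CCN(C(=O)OC)CC2)CC1` gives "not determined" (no result reported)
compound 3 `CCNC(=O)Nc1sc2ccccc2c1C(=O)N1CCN(C2CCN(C(=O)OCC)CC2)CC1` gives 228 nM

These three compounds share one core and belong to a functional assay on HepG2 cells (Homo sapiens) for inhibition, read by scintillation counting, with a stated time of 2 h (on this read-out lower numbers stand for stronger inhibition and higher numbers for weaker inhibition), yet only compound 3 has a number, 228 nM, to show for it. Compounds 1 and 2 have no result reported, so compound 3 cannot be ranked against them. It is a lone reference point, neither high nor low on any scale that the data can draw.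

Compound 4 `CCNC(=O)Nc1sc2ccccc2c1C(=O)N1CCN(C2CCN(C(=O)OC(C)(C)CF)CC2)CC1` is still to be measured in this assay. It keeps all of compound 3 except one group: 1-(fluoromethyl)-1-methylethyl in place of ethyl on an oxygen next to a carbonyl group. In words, 1-(fluoromethyl)-1-methylethyl stands in place of ethyl on an oxygen next to a carbonyl group.

Among the compounds with values here, no pair of measured compounds shows what a change at this place does, so the forecast has only one anchor and needs a wide range. A modest shift towards stronger inhibition is expected, close to the usual scatter of repeated measurements, and the estimate is a 2.1-fold lower number from compound 3 to compound 4 (0.32 log units; beyond the scatter). For compound 4 the estimated value is 110 nM, with an expected range from 30 nM to 400 nM.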

Compound 4, half-maximal inhibitory concentration: 61 nM
Estimate against measurement, compound 4: 1.8-fold (0.26 log units) above, within the range that was stated.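

In this assay, within the data shown here, 1-(fluoromethyl)-1-methylethyl in place of ethyl on an oxygen next to a carbonyl group gives a 3.7-fold lower number from compound 3 to compound 4 (0.57 log units; beyond the scatter), the first measured step at this position. The entering group has 5 heavy atoms against 2 for ethyl, so this position can take a clearly larger group without any loss of inhibition, and in this one case inhibition becomes stronger by more than the usual variation between repeated measurements. Nothing in the data explains why the number falls, so this remains an observed change with no established cause.

The swap changes the size and shape of the group and brings in fluorine at the same time, so the compounds shown leave open which of these matters; a tert-butyl group, which has the same branched carbon framework without the fluorine, would help to separate them. Going by these compounds, it also remains open how a longer unbranched chain such as n-butyl, or a group carrying an amine or a carboxylic acid, would behave at this position.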